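The source may hold more compounds than are shown below. What is called first, only, known or untested is meant among the compounds shown, and "the series" means these compounds.

Working notes on the series.

The three measured compounds share one core and differ only in the substituent on the pendant benzene ring. Compound 1 `COc1ccccc1CSc1nc2ccccc2n1CC(=O)O` carries a methoxy group there and, in an assay on HEK293 cells for displacement of a labelled ligand from prostaglandin D2 receptor 2 (Homo sapiens) (a higher number here means a weaker inhibitor, a lower number a stronger inhibitor), compound 1 gives 1100 nM, the highest number among the three. Compound 2 `O=C(O)Cn1c(SCc2ccccc2Br)nc2ccccc21` has bromo in place of that methoxy and in this assay compound 2 gives 580 nM; the shift is a 1.9-fold lower number from compound 1 to compound 2 (0.28 log units; within the scatter). Compound 3 `COC(=O)c1ccccc1CSc1nc2ccccc2n1CC(=O)O` has methoxycarbonyl in place of methoxy and in this assay compound 3 gives 520 nM, a shift of a 2.1-fold lower number from compound 1 to compound 3 (0.33 log units; beyond the scatter) from compound 1. Between the two replacements the gap is a 1.1-fold lower number from compound 2 to compound 3 (0.05 log units; within the scatter).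

Compound 4 `COc1ccc(Cl)cc1CSc1nc2ccccc2n1CC(=O)O` keeps the methoxy of compound 1 and adds a further group: chloro in place of hydrogen on an aromatic carbon, placed meta to a large group and para to the methoxy group. None of the three measured steps covers this change; all of them swap the existing substituent rather than adding a second one, so they only show that single changes on this ring have so far moved this assay by modest amounts. On that basis a small step is expected for compound 4, most likely a somewhat lower number than compound 1, with wide uncertainty.

Compound 4 is estimated at 700 nM in this assay, between 250 nM and 2000 nM, which corresponds to an expected step of a 1.6-fold lower number from compound 1 to compound 4 (0.20 log units; within the scatter).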

Compound 4, half-maximal inhibitory concentration: 740 nM
Compound 4: the middle estimate sits 1.1-fold (0.02 log units) below what was measured, and the stated range covers the measured number.
By their numbers in this assay, from the lowest: compounds 3, 2, 4 and 1 (each within the scatter of the next, the first and the last beyond it).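

Among these compounds, compound 4 is the first entry in which a group is added to the pendant benzene ring while the methoxy stays in place: chloro in place of hydrogen, meta to a large group and para to the methoxy group. In this assay this addition gives a 1.5-fold lower number from compound 1 to compound 4 (0.17 log units; within the scatter), so the series now holds a ring with two substituents, and the step from the added chloro cannot be told apart from repeat measurements of compound 1. No measurement of any other property of these compounds is available to account for this step.

Because only chloro is shown at this position, and only with the methoxy group retained, it remains open whether a larger group such as trifluoromethyl, or a group of a different kind such as an amine or a nitrile, would move the number beyond the scatter. As far as these compounds go, it is equally open whether chloro at this position would give a similar step alongside the bromo of compound 2 or the methoxycarbonyl of compound 3.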